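Amide in place of ketone on a weakly active core

The source may report more compounds than this note shows. Statements on the series, on what has been measured and on what is new or still open speak of the compounds shown alone.

Measured so far in a functional assay on HepG2 cells (Homo sapiens) for antiproliferative activity, read by MTT assay, with a stated time of 48 h; a lower number here means a stronger inhibitor, a higher number a weaker inhibitor:
Compound 1, `COc1cc(-c2nnc(SCC(=O)c3ccc(C(F)(F)F)cc3)n2N)cc(OC)c1OC`: > 100000 nM, a limit of the assay rather than a number.
Compound 2, `COc1cc(-c2nnc(SCC(=O)c3cccc(Br)c3)n2N)cc(OC)c1OC`: 56000 nM.

Compound 2 holds the only finite number shown; the other value is a limit. Among the measured compounds shown here, the single measured step, an at least 1.7-fold lower number from compound 1 to compound 2 (0.25 log units; that floor lies within the scatter), is anchored on (the limit of > 100000 nM in this assay, at which 1 of the 2 values shown sits), so it sets no firm direction. Compound 3, `COc1cc(-c2nnc(SCC(=O)Nc3ccccc3)n2N)cc(OC)c1OC`, differs from compound 2 by anilino in place of 3-bromophenyl on a carbonyl carbon; cut one bond further out, this reads as (3-bromophenyl)carbonyl to phenylcarbamoyl. No measured step touches this change, so the expectation rests on compound 2 alone and on the weak range both shown values occupy. A step of about a 1.4-fold higher number from compound 2 to compound 3 (0.15 log units; within the scatter) is therefore expected, not clearly beyond the scatter in either direction. Compound 3 is estimated at 80000 nM in this assay, with a range from 20000 nM to 300000 nM.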

Compound 3, half-maximal inhibitory concentration: 49900 nM
Beside the measured number, compound 3's estimate is 1.6-fold (0.20 log units) above it, and the stated range covers the measured number.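

The step of a 1.1-fold lower number from compound 2 to compound 3 (0.05 log units; within the scatter) shows that in this assay, anilino and 3-bromophenyl on a carbonyl carbon cannot be told apart, even though anilino brings a hydrogen-bond donor that 3-bromophenyl lacks and the bromine is gone. At this place, then, the ketone of compound 2 and the amide of compound 3 both leave the shared core in the same weak range. The other new step, an at least 2.0-fold lower number from compound 1 to compound 3 (0.30 log units; that floor lies within the scatter), sets no firm direction. Compound 1 gives a limit of the assay rather than a number, and that step rests on it: the limit of > 100000 nM in this assay, at which 1 of the 3 values shown sits.

From the compounds shown here alone, what a 3-bromoanilino group, an amine or a carboxylic acid on this carbonyl carbon would give remains open. So does whether any group here can bring the shared core out of this weak range.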